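The source may report more compounds than this note shows. Statements on the series, on what has been measured and on what is new or still open speak of the compounds shown alone.

Measured in a functional assay on PC-3 cells (Homo sapiens) for antiproliferative activity, read by MTT assay, with a stated time of 96 h; a lower number here means a stronger inhibitor of growth, a higher number a weaker inhibitor of growth:
compound 1 `Oc1cccc2ccc(Nc3cc(Cl)ccn3)nc12`: 2810 nM
compound 2 `Cc1ccnc(Nc2ccc3c(Cl)ccc(O)c3n2)c1`: 10200 nM

Of these two, compound 2 stands highest at 10200 nM, which makes it the weaker inhibitor of growth. Its gap to compound 1 lies beyond the usual scatter. The next compound to be tested in this assay is compound 3 `Oc1ccc(Cl)c2ccc(Nc3cc(Cl)ccn3)nc12`, which departs from compound 2 by chloro in place of methyl on an aromatic carbon. Among the compounds with values here, no measured pair isolates this change, so the expectation rests on one comparison. Compound 1 also carries chloro on that ring, and it gives 2810 nM. A moderate move toward a lower number is therefore expected, somewhat beyond the scatter. The estimated step is a 2.9-fold lower number from compound 2 to compound 3 (0.46 log units; beyond the scatter). For compound 3 the expected value is 3500 nM, with an estimated range from 1200 nM to 9000 nM.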

Compound 3, concentration for 50% growth inhibition: 25500 nM
Beside the measured number, compound 3's estimate is 7.3-fold (0.86 log units) below it, and the stated range ends below it.
By their numbers in this assay, from the lowest: compound 1; then compound 2; then compound 3.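

In this assay, the swap of methyl for chloro on the ring with one nitrogen, opposite the ring nitrogen, gives a 2.5-fold higher number from compound 2 to compound 3 (0.40 log units; beyond the scatter), so with chloro already on the core, this place favours methyl over chloro. Chloro at this place goes with the lowest number only in compound 1, which has hydrogen where compound 3 has its core chloro, and putting chloro in place of that hydrogen gives a 9.1-fold higher number from compound 1 to compound 3 (0.96 log units; beyond the scatter). No accompanying measurement accounts for either step.

Whether methyl would also be favoured over chloro at this place with hydrogen on the core remains open, since the compounds shown pair methyl only with the core chloro. They also leave open how a methoxy group, a fluoro group or an amine would fare at this place.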